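A 3-(piperidin-1-yl)propyl group replaces the arm of compound 3

The compounds below may be only part of what the source reports. "The series", "measured", "known", "first", "only" and "open" are said of these compounds alone.

- Compound 1 `COc1cc(OC)c2c(=O)c(OCC(=O)N/N=C/c3sccc3C)c(-c3cc(OC)c(OC)c(OC)c3)oc2c1` gives 4470 nM
- Compound 2 `COc1cc(OC)c2c(=O)c(OCC(=O)N/N=C/c3ccc(C)cc3)c(-c3cc(OC)c(OC)c(OC)c3)oc2c1` gives 4570 nM
- Compound 3 `COc1cc(OC)c2c(=O)c(OCC(=O)N/N=C/c3ccccc3F)c(-c3cc(OC)c(OC)c(OC)c3)oc2c1` gives 3400 nM

In a functional assay on MDA-MB-231 cells (Homo sapiens) for cytotoxicity, read by MTT assay, with a stated time of 38 h (on this read-out higher numbers stand for weaker inhibition and lower numbers for stronger inhibition), the three compounds are not separated from one another. Compound 3 stands level with the other two, as a 1.3-fold lower number from compound 1 to compound 3 (0.12 log units; within the scatter) and a 1.3-fold lower number from compound 2 to compound 3 (0.13 log units; within the scatter) show, and a 1.0-fold higher number from compound 1 to compound 2 (0.01 log units; within the scatter) tells the same story.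

Compound 4 `COc1cc(OC)c2c(=O)c(OCCCCN3CCCCC3)c(-c3cc(OC)c(OC)c(OC)c3)oc2c1` differs from compound 3 by a group of 9 heavy atoms (8 carbon, 1 nitrogen; one six-membered non-aromatic ring with 1 hetero atom) in place of a group of 12 heavy atoms (8 carbon, 2 nitrogen, 1 oxygen, 1 fluorine; one six-membered aromatic ring of carbon only), on a saturated chain carbon bound to an oxygen on an aromatic ring and the group that enters is 3-(piperidin-1-yl)propyl. The measured steps bear on this only weakly. Each swaps one ring group for another at the end of the arm, and none removes the arm, so the data give no direction for the new change. The expectation therefore starts from compound 3 (3400 nM) and its range stays wide. The expected change is a 1.4-fold lower number from compound 3 to compound 4 (0.13 log units; within the scatter) and no firm direction is implied. Compound 4 is estimated at 2500 nM with an expected range of 700 nM to 9000 nM in this measurement.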

Compound 4, half-maximal inhibitory concentration: 3030 nM
For compound 4 the middle estimate is 1.2-fold (0.08 log units) below the measured one; the range from low to high includes it.
By their numbers in this assay, from the lowest: compounds 4, 3, 1 and 2 (each within the scatter of the next).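

Within the data shown here, on the saturated chain carbon bound to an oxygen on an aromatic ring, the earlier compounds varied only the ring at the end of the arm, whereas here the whole arm gives way to 3-(piperidin-1-yl)propyl, and in this assay the numbers stay level: a 1.1-fold lower number from compound 3 to compound 4 (0.05 log units; within the scatter), a 1.5-fold lower number from compound 2 to compound 4 (0.18 log units; within the scatter) and a 1.5-fold lower number from compound 1 to compound 4 (0.17 log units; within the scatter). The group leaving compound 3 holds a hydrogen-bond donor and an aromatic ring, the entering group holds neither, and this difference produces no separable shift at this position. Nothing available explains this result.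

The compounds shown leave open whether any group here would separate from these four, such as a morpholine ring in place of the piperidine ring or a carboxylic acid at the end of the chain. They also leave open how a shorter chain carrying the same piperidine ring would read.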